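Methyl on the Aromatic Nitrogen: Compound 1 to Compound 4

The source may hold more compounds than are shown below. What is called first, only, known or untested is meant among the compounds shown, and "the series" means these compounds.

Three compounds were measured in an assay on a protein complex for inhibition of CDK8/Cyclin C (Homo sapiens), with a stated time of 1 h, tested at 10 uM; a lower number here means less inhibition, a higher number more inhibition at the concentration tested (going by the name of the read-out):

compound 1 `CCOC(=O)/C=C/c1ccncc1-c1ccc2[nH]ccc2c1` gives 100%
compound 2 `O=C(O)/C=C/c1ccncc1-c1ccc2cc[nH]c2c1` gives 103%
compound 3 `NC(=O)/C=C/c1ccncc1-c1ccc2ccccc2c1` gives 102%

Compound 1 has the lowest of the three numbers, yet its nearest neighbour, compound 3, and its furthest, compound 2, both sit within the scatter of it, so the three cannot be ordered. Compound 4 `CCOC(=O)/C=C/c1ccncc1-c1ccc2c(ccn2C)c1` differs from compound 1 by methyl in place of hydrogen on an aromatic nitrogen. Within the data shown here, no measured pair here carries this change, so its effect is unknown; with the number of compound 1 already high, the step could be none beyond the scatter or a modest move to a lower number. Compound 4 is expected to give 90% (60% to 103%), an estimated step of a number 10 percentage points lower from compound 1 to compound 4 (within the scatter).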

Compound 4, a percentage reported as inhibition, at one concentration (the size of the read-out at that concentration, not a potency): 100%
Estimate against measurement, compound 4: 10 percentage points below, and the stated range covers the measured number.
By their numbers in this assay, from the lowest: compounds 1, 4, 3 and 2 (each within the scatter of the next).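

The step gives no change at the digits printed from compound 1 to compound 4 (within the scatter) and shows that, in this assay, this aromatic nitrogen can carry methyl in place of hydrogen without a change beyond the scatter. The hydrogen on it is therefore not needed for the inhibition read at the one concentration tested, though this read-out is not a potency and could hide a difference in potency. No evidence on hand accounts for this result.

As far as these compounds go, whether an ethyl group, a longer chain or an acetyl group on this nitrogen would be accepted stays open. So does whether methyl and hydrogen differ at lower concentrations.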